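Benzoyl to 2-phenylethenyl: cytotoxicity on BJ cells

This account rests on a few compounds, and the source may have more. Where it says the series, first, only, none or still open, it means among the compounds named here.

Of the compounds shown here, two have so far been tested in an ADME assay on BJ cells (Homo sapiens) for cytotoxicity, with a stated time of 72 h; on this read-out higher numbers stand for an effect only at larger amounts of compound and lower numbers for an effect already at smaller amounts. Compound 1 `C=C[C@@](C)(/C=C/c1ccc(O)cc1)CC/C=C(\C)C=O` gives in this assay only a limit of the assay, > 36600 nM. Compound 2 `C=C[C@@](C)(/C=C/c1ccc(O)c(/C=C/C(=O)c2ccccc2)c1)CCC=C(C)C` likewise reaches only a limit in this assay, > 20000 nM. Compound 2 thus stands among limits alone: both values shown are limits, recorded as the limit of > 20000 nM in this assay, at which 1 of the 2 values shown sits, and (the limit of > 36600 nM in this assay, at which 1 of the 2 values shown sits), and neither places a compound at a definite number.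

Compound 3 `C=C[C@@](C)(/C=C/c1ccc(O)c(/C=C/C=C/c2ccccc2)c1)CCC=C(C)C` has not yet been measured in this assay. It differs from compound 2 in one place: 2-phenylethenyl in place of benzoyl on a double-bonded chain carbon bound to a double-bonded chain carbon.

Within the data shown here, no step between measured compounds is available, so the size of the coming step can only be judged from the two limits. With both measured values at limits, the limit of > 20000 nM in this assay, at which 1 of the 2 values shown sits, and (the limit of > 36600 nM in this assay, at which 1 of the 2 values shown sits), no step beyond the usual scatter is expected in this assay, and the most likely outcome is once more a limit. Compound 3 is therefore expected at 25000 nM in this assay, within 8000 nM to 60000 nM. This corresponds to an expected step that the limit leaves unreadable from compound 2 to compound 3.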

Compound 3, half-maximal effective concentration: > 36600 nM
Compound 3 ended at the assay's limit (the forecaster's own chance of this, stated with the estimate: 70%); middle value at least 1.4-fold (0.16 log units) away from the limit.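

Compound 2 and compound 3 both end at limits in this assay, so the step from 2-phenylethenyl in place of benzoyl on a double-bonded chain carbon bound to a double-bonded chain carbon cannot be read. The compounds shown leave open at what amount, if any, either compound has an effect, and whether this exchange changes it.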